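The source may hold more compounds than are shown below. What is called first, only, known or untested is meant among the compounds shown, and "the series" means these compounds.

Compound 3 `COc1ccc(S(=O)(=O)N(C)c2ccc3[nH]c(-c4n[nH]c5ccccc45)cc3n2)cc1` stands, in a functional assay on HCT-116 cells (Homo sapiens) for antiproliferative activity, read by MTT assay, with a stated time of 72 h (a higher number here means a weaker inhibitor, a lower number a stronger inhibitor), at 22400 nM, the highest of the three numbers recorded. Compound 1 `CN(c1ccc2[nH]c(-c3n[nH]c4ccccc34)cc2n1)S(=O)(=O)c1ccccc1` gives 6740 nM and compound 2 `CN(c1ccc2[nH]c(-c3n[nH]c4ccccc34)cc2n1)S(=O)(=O)c1ccc(Br)cc1` gives 9850 nM; the step of a 3.3-fold higher number from compound 1 to compound 3 (0.52 log units; beyond the scatter) is modest but beyond the scatter, as is a 2.3-fold higher number from compound 2 to compound 3 (0.36 log units; beyond the scatter), while a 1.5-fold higher number from compound 1 to compound 2 (0.16 log units; within the scatter) stays within it. Compound 4 `COc1ccc(S(=O)(=O)N(C)c2ccc3[nH]c(-c4n[nH]c5ccccc45)cc3n2)c(OC)c1` differs from compound 3 by methoxy in place of hydrogen on an aromatic carbon. Going by the values given here, the one step that bears on it is the earlier introduction of a methoxy, a 3.3-fold higher number from compound 1 to compound 3 (0.52 log units; beyond the scatter), which raised the number modestly. A second methoxy on the same ring is therefore expected to leave this assay unchanged or to raise it further by a modest amount, estimated as a 1.4-fold higher number from compound 3 to compound 4 (0.15 log units; within the scatter). For compound 4 the expected value is 32000 nM, within a range from 12000 nM to 80000 nM.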

Compound 4, half-maximal inhibitory concentration: 21800 nM
Compound 4: the middle estimate sits 1.5-fold (0.17 log units) above what was measured; the range from low to high includes it.
By their numbers in this assay, from the lowest: compounds 1 and 2 (each within the scatter of the next); then compounds 4 and 3 (each within the scatter of the next).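

In this assay the step of a 1.0-fold lower number from compound 3 to compound 4 (0.01 log units; within the scatter) shows that a methoxy can be added ortho to a large group on the 4-methoxyphenyl ring with no change beyond the scatter. The 2,4-dimethoxyphenyl ring still gives modest steps, with a 2.2-fold higher number from compound 2 to compound 4 (0.35 log units; beyond the scatter) and with a 3.2-fold higher number from compound 1 to compound 4 (0.51 log units; beyond the scatter) as well. Nothing available accounts for these results.

The compounds shown leave open whether an amine or a carboxylic acid at this place would be tolerated equally. They also leave open what a methoxy here would do without the one already on the ring.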